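A few compounds are considered here, and "the series" means these few. Any claim that something is new, unique, unknown or untested is made for them only; others in the source may bear on it.

Measured so far:
compound 1, `Nc1cc(N)c2nc(-c3ccccc3)c(NCc3ccc(F)cc3)nc2c1` — 40700 nM
compound 2, `Nc1cc(N)c2nc(-c3ccccc3)c(Sc3ccc(Cl)c(Cl)c3)nc2c1` — < 100000 nM

In a functional assay on NCI-H322M cells (Homo sapiens) for inhibition, read by sulforhodamine B assay, with a stated time of 48 h (a lower number here means that less compound is tolerated, a higher number that more compound is tolerated), compound 1 gives 40700 nM. For compound 2 the assay gives only a limit, < 100000 nM; no number stands for it. The step that the limit leaves unreadable from compound 1 to compound 2 therefore cannot be sized, because of the limit of < 100000 nM in this assay, at which 1 of the 2 values shown sits. Where compound 2 stands is thus known only as a limit, and any comparison with compound 1 rests on that limit alone.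

Compound 3, `Nc1cc(N)c2nc(-c3ccccc3)c(Sc3ccc(F)cc3)nc2c1`, differs from compound 2 by 4-fluorophenyl in place of 3,4-dichlorophenyl on a sulfur. Among the measured compounds shown here, no measured step touches this change: the single step on record, from compound 1 to compound 2, exchanges the whole (4-fluorobenzyl)amino group for (3,4-dichlorophenyl)sulfanyl and is unreadable. The expectation for compound 3 can rest only on the weak activity of both measured compounds and on the small size of the swap on the sulfur. For compound 3 the step that the limit leaves unreadable from compound 2 to compound 3 is expected to stay within the usual scatter. Compound 3 is estimated at 50000 nM, with a range from 15000 nM to 150000 nM in this assay, and a fair chance that only a limit is reported.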

Compound 3, concentration lethal to 50% of the cells: 70800 nM
Compound 3: middle estimate off by 1.4-fold (0.15 log units), on the low side; the measured number falls inside the stated range.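

Among the compounds shown here, the first readable comparison at this position is the change to (4-fluorophenyl)sulfanyl in place of (4-fluorobenzyl)amino on an aromatic carbon: in this assay, it is a 1.7-fold higher number from compound 1 to compound 3 (0.24 log units; within the scatter). This read-out therefore does not separate these two groups, and a sulfur-linked aryl group and a benzylamino group both have a measured number in the same series. Compound 2 has only a limit, < 100000 nM, and the steps that involve it cannot be read, so the exchange of 3,4-dichlorophenyl for 4-fluorophenyl on a sulfur stays unsized: the limit of < 100000 nM in this assay, at which 1 of the 3 values shown sits.

On these data alone, all three compounds share the same core, so the part played by its two amino groups and its phenyl group remains open. As far as these compounds go, it is also open whether a different group at this position, such as a morpholine, a carboxylic acid or a longer alkyl chain on the sulfur, would move the number beyond the scatter.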